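The compounds below may be only part of what the source reports. "The series", "measured", "known", "first", "only" and "open" are said of these compounds alone.

In a functional assay, read by Griess assay, with a stated time of 2.5 h (a lower number here means a stronger inhibitor, a higher number a weaker inhibitor), compound 1, `COc1cc(OC)c(OC)cc1/C=C/C(=O)c1cc(Cl)ccc1O`, gives 2.32 ug/mL, which puts it second highest of the three numbers that have been measured. Compound 3, `COc1cc(OC)c(C2CC(=O)c3cc(O)ccc3O2)cc1OC`, gives 2.43 ug/mL in this assay, and compound 2, `COc1cc(OC)c(OC)cc1/C=C/C(=O)c1ccc(Cl)c([N+](=O)[O-])c1`, gives 1.99 ug/mL; both lie within the usual scatter of the number for compound 1, so no order among these three can be drawn. Compound 4, `COc1cc(OC)c(OC)cc1/C=C/C(=O)c1ccc(Br)cc1`, has not yet been measured. It differs from compound 1 in one place: 4-bromophenyl in place of 5-chloro-2-hydroxyphenyl on a carbonyl carbon. Among the compounds with values here, with no measured step of this kind to lean on, the account expects the step of a 1.3-fold higher number from compound 1 to compound 4 (0.11 log units; within the scatter) to be small, if anything toward a weaker inhibitor. Compound 4 is therefore estimated at 3 ug/mL, with a range from 1.2 ug/mL to 8 ug/mL.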

Compound 4, half-maximal inhibitory concentration: 2.22 ug/mL
Beside the measured number, compound 4's estimate is 1.4-fold (0.13 log units) above it; the measured number falls inside the stated range.
By their numbers in this assay, from the lowest: compounds 2, 4, 1 and 3 (each within the scatter of the next).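

The step is a 1.0-fold lower number from compound 1 to compound 4 (0.02 log units; within the scatter) in this assay, so at this place, on a carbonyl carbon, 5-chloro-2-hydroxyphenyl can give way to 4-bromophenyl without the number leaving the scatter. The entering group has no hydrogen-bond donors or acceptors, whereas the leaving group has one of each, and this difference in counts comes with no readable change here. Nothing available explains this result. The compounds shown leave open whether an amine or a carboxylic acid in place of the bromine would also stay within the scatter. They also leave open how a ring-free group, such as a longer chain, would fare on this carbonyl carbon.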